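Pyridin-4-yl in place of 1-methylpiperidin-4-yl on a carbonyl carbon

This account rests on a few compounds, and the source may have more. Where it says the series, first, only, none or still open, it means among the compounds named here.

Compound 1 `O=C(Nc1cccc(Nc2ncc(F)c(Nc3ccc(F)cc3)n2)c1)c1cnccn1` gives 20100 nM in a functional assay on KBVIN cells (Homo sapiens) for antiproliferative activity, read by sulforhodamine B assay, with a stated time of 3 days; on this read-out lower numbers stand for stronger inhibition of growth and higher numbers for weaker inhibition of growth
Compound 2 `CN1CCC(C(=O)Nc2cccc(Nc3ncc(F)c(Nc4ccc(F)cc4)n3)c2)CC1` gives 11900 nM in this assay

With only these two measurements, compound 2 has a single neighbour to be compared with, and the two cannot be told apart: the measured step is a 1.7-fold lower number from compound 1 to compound 2 (0.23 log units; within the scatter) and is the only one that bears on what follows. It exchanged pyrazin-2-yl for 1-methylpiperidin-4-yl on the same carbonyl carbon and left the shared core untouched.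

Compound 3 `O=C(Nc1cccc(Nc2ncc(F)c(Nc3ccc(F)cc3)n2)c1)c1ccncc1` changes that same place again: pyridin-4-yl in place of 1-methylpiperidin-4-yl on a carbonyl carbon gives pyridin-4-yl in place of 1-methylpiperidin-4-yl on a carbonyl carbon. For the measured compounds named here, the one earlier exchange at this carbon stayed within the scatter, and the entering group is aromatic, as is the group of compound 1 (20100 nM). No change beyond the scatter is therefore expected in this assay, though two compounds are thin support. The expected size of the change is a 1.3-fold higher number from compound 2 to compound 3 (0.10 log units; within the scatter) and it is only an estimate. For compound 3 the estimated value is 15000 nM, with an expected range from 7000 nM to 30000 nM as the likely outcome.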

Compound 3, concentration for 50% growth inhibition: 4570 nM
Compound 3: the middle estimate sits 3.3-fold (0.52 log units) above what was measured; measured number outside the range, below it.
By their numbers in this assay, from the lowest: compound 3; then compounds 2 and 1 (each within the scatter of the next).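

In this assay the group on this carbonyl carbon now moves the number beyond the scatter, which the step between the two earlier compounds did not do: pyridin-4-yl in place of 1-methylpiperidin-4-yl gives a change (a 2.6-fold lower number from compound 2 to compound 3 (0.42 log units; beyond the scatter)), and pyridin-4-yl in place of pyrazin-2-yl gives a somewhat larger one (a 4.4-fold lower number from compound 1 to compound 3 (0.64 log units; beyond the scatter)). Compound 3 therefore has the lowest number of the three, with its steps to both others beyond the scatter, and being aromatic does not settle the outcome at this carbon, since the pyrazin-2-yl group of compound 1 is aromatic too and lies on the other side of the step. Nothing at hand accounts for why pyridin-4-yl stands apart from either group.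

From the compounds shown here alone, whether the gain depends on the ring nitrogen of pyridin-4-yl stays open, because a plain phenyl ring, pyridin-3-yl or pyridin-2-yl on the same carbonyl carbon would be needed to tell. Going by these compounds, it is also open how an open-chain group such as dimethylaminomethyl would compare at this place, and whether the steps hold in any other cell line.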